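Pyrimidine Swap on the Sulfonamide Nitrogen of Compound 3

This account rests on a few compounds, and the source may have more. Where it says the series, first, only, none or still open, it means among the compounds named here.

Three compounds share one core and differ only in the group on the sulfonamide nitrogen. In a functional assay on T47D cells (Homo sapiens) for cytotoxicity, read by sulforhodamine B assay, with a stated time of 48 h (a higher number here means a weaker inhibitor, a lower number a stronger inhibitor), compound 1 `CC(=O)NS(=O)(=O)c1ccc(N/C=C\C(=O)c2cc3ccccc3oc2=O)cc1` has no result reported. In this assay compound 2 `Cc1cc(NS(=O)(=O)c2ccc(N/C=C\C(=O)c3cc4ccccc4oc3=O)cc2)on1` gives 75600 nM, and compound 3 `Cc1ccnc(NS(=O)(=O)c2ccc(N/C=C\C(=O)c3cc4ccccc4oc3=O)cc2)n1` gives 24500 nM, the lowest number of the two that are known. Among the compounds with values here, the only measured step is a 3.1-fold lower number from compound 2 to compound 3 (0.49 log units; beyond the scatter), a change of the heteroaryl on that same nitrogen.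

Compound 4 `Cc1cc(NS(=O)(=O)c2ccc(N/C=C\C(=O)c3cc4ccccc4oc3=O)cc2)nc(C)n1` carries 2,6-dimethylpyrimidin-4-yl in place of 4-methylpyrimidin-2-yl on a sulfonamide nitrogen. Within the data shown here, the step from compound 2 to compound 3 is the sole guide, and it bears on the present change only loosely: both exchanges alter the heteroaryl on the sulfonamide nitrogen, but here the ring type stays a pyrimidine and only the methyl count and attachment change. A step of at most modest size is therefore expected, in either direction, and most likely none beyond the scatter.

Compound 4 is estimated to give 30000 nM, with a range from 10000 nM to 90000 nM. This estimate means an expected 1.2-fold higher number from compound 3 to compound 4 (0.09 log units; within the scatter).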

Compound 4, half-maximal inhibitory concentration: 100000 nM
Compound 4: the middle estimate sits 3.3-fold (0.52 log units) below what was measured, outside the stated range (above it).
By their numbers in this assay, from the lowest: compound 3; then compounds 2 and 4 (each within the scatter of the next).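

In this assay, a pyrimidine on the sulfonamide nitrogen does not by itself keep the number low: 2,6-dimethylpyrimidin-4-yl in place of 4-methylpyrimidin-2-yl gives a 4.1-fold higher number from compound 3 to compound 4 (0.61 log units; beyond the scatter), so the change matters even though the ring type stays the same. Compound 4 also does not separate from the 3-methyl-1,2-oxazol-5-yl compound, with a 1.3-fold higher number from compound 2 to compound 4 (0.12 log units; within the scatter), which leaves compound 3 alone in standing apart from both others by more than the scatter. Nothing in the data available explains why this one group differs from the other two.

The change from compound 3 to compound 4 alters both the methyl count and the attachment of the ring at once, so the two effects cannot be told apart. On these data alone, an unsubstituted pyrimidin-2-yl or a 4,6-dimethylpyrimidin-2-yl on the same nitrogen would be needed to separate them, and how either would read remains open.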